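Methyl for Hydrogen on a Chain Carbon: Compound 4

The source may report more compounds than this note shows. Statements on the series, on what has been measured and on what is new or still open speak of the compounds shown alone.

Measured so far:
- compound 1, `Cc1nn(C)c2c1C(c1cccc(C(F)(F)F)c1)=NCCN2`: 0.63 mg/kg
- compound 2, `CCn1nc(C)c2c1NCCN=C2c1cccc(C(F)(F)F)c1`: 0.63 mg/kg
- compound 3, `Cc1nn(C)c2c1C(c1cccc(F)c1)=NCCN2`: 2.5 mg/kg

In a functional assay on the whole organism for positive allosteric modulation, with Rattus norvegicus as the target (on this read-out higher numbers stand for an effect only at larger amounts of compound and lower numbers for an effect already at smaller amounts), compound 1 gives 0.63 mg/kg, and compound 2 gives 0.63 mg/kg. The change from compound 1 to compound 2 is methyl in place of hydrogen on a saturated chain carbon bound to an aromatic nitrogen, and its step is no change at the digits printed from compound 1 to compound 2 (within the scatter). Compound 3 gives 2.5 mg/kg in this assay; its core differs from that of compound 1 by fluoro in place of trifluoromethyl on an aromatic carbon, a step of a 4.0-fold higher number from compound 1 to compound 3 (0.60 log units; beyond the scatter).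

Compound 4, `CCc1nn(C)c2c1C(c1cccc(F)c1)=NCCN2`, is not yet measured. It differs from compound 3 by methyl in place of hydrogen on a saturated chain carbon bound to an aromatic carbon. This is the same kind of change as that from compound 1 to compound 2, but not the same: the place is a saturated chain carbon bound to an aromatic carbon rather than one bound to an aromatic nitrogen. Because the earlier step was no change at the digits printed from compound 1 to compound 2 (within the scatter), compound 4 is expected to sit near compound 3, with an estimated step of no change at the digits printed from compound 3 to compound 4 (within the scatter). Compound 4 is thus estimated at 2.5 mg/kg in this assay, between 1.25 mg/kg and 5 mg/kg.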

Compound 4, minimum effective dose: 2.5 mg/kg
Compound 4: the middle estimate sits on the measured number at the digits printed; measured number inside the range.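

In this assay the step of methyl in place of hydrogen on a saturated chain carbon bound to an aromatic carbon reads no change at the digits printed from compound 3 to compound 4 (within the scatter). Set beside the earlier step on the core of compound 1, the new step agrees with it: the same change on two cores in this assay, no change at the digits printed (within the scatter) from compound 1 to compound 2 and no change at the digits printed (within the scatter) from compound 3 to compound 4, 1.0-fold (0.00 log units) apart, within the scatter of two such steps. Within these four compounds, then, adding this methyl leaves the minimum effective dose unresolved from that of the parent on both the trifluoromethyl and the fluoro cores, but the evidence is one pair per core, the carbon that takes the methyl is bound to an aromatic nitrogen in one pair and to an aromatic carbon in the other, and nothing here shows that the result would hold on a third core.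

The compounds shown leave open whether a longer chain, such as propyl or butyl, would read the same at either place. They also leave open what an amine or a carboxylic acid on that chain would do.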